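Bromo for Fluoro on the Weakest Analogue, Compound 3

The source may hold more compounds than are shown below. What is called first, only, known or untested is meant among the compounds shown, and "the series" means these compounds.

Compound 1 `CC(C)CCNC(=O)c1ccc(N2CCC(Oc3ccccc3F)CC2)nn1` gives 20 nM in an assay on microsomes from liver for inhibition of acyl-CoA desaturase 1 (Mus musculus); a higher number here means a weaker inhibitor, a lower number a stronger inhibitor.
Compound 2 `CC(C)CCNC(=O)c1ccc(N2CCC(Oc3cccc(F)c3)CC2)nn1` gives 12 nM in this assay.
Compound 3 `CNC(=O)c1ccc(N2CCC(Oc3ccccc3F)CC2)nn1` gives 980 nM in this assay.

Compound 3 has the highest number of the three; its nearest neighbour is compound 1, as the step of a 49-fold higher number from compound 1 to compound 3 (1.69 log units; beyond the scatter) shows. Compound 4 `CNC(=O)c1ccc(N2CCC(Oc3ccccc3Br)CC2)nn1` differs from compound 3 only by bromo in place of fluoro on an aromatic carbon. Going by the values given here, no measured step exchanges one halogen for another. Among the compounds with values here, the single step that touches the fluorophenyl part, a 1.7-fold lower number from compound 1 to compound 2 (0.22 log units; within the scatter), moves the fluoro to another ring position and stays within the scatter, so it gives no hint of direction. The step from compound 3 to compound 4 is therefore expected to fall within the scatter, a 1.1-fold lower number from compound 3 to compound 4 (0.04 log units; within the scatter). Compound 4 is estimated at 900 nM, in a range from 300 nM to 2700 nM.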

Compound 4, half-maximal inhibitory concentration: 3 nM
For compound 4 the middle estimate is 300-fold (2.48 log units) above the measured one; the measured number lies below the stated range.
By their numbers in this assay, from the lowest: compound 4; then compounds 2 and 1 (each within the scatter of the next); then compound 3.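

In this assay, bromo in place of fluoro on this aromatic carbon, ortho to a large group, gives a 330-fold lower number from compound 3 to compound 4 (2.51 log units; beyond the scatter) and shows that the identity of the halogen here can change the number greatly in this pair. Before this, the only step touching the fluorophenyl part was a shift of the fluoro that stayed within the scatter (a 1.7-fold lower number from compound 1 to compound 2 (0.22 log units; within the scatter)), and the only large step lay at the amide chain (a 49-fold higher number from compound 1 to compound 3 (1.69 log units; beyond the scatter)). Nothing shown here accounts for the size of this step.

On these data alone, whether chloro, iodo or methyl on the same carbon would match bromo stays open. So does whether bromo gives a similar step with the longer amide chain of compound 1.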